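Triazole dithiocarbamates: from 2-fluorophenyl to 3,4-dichlorobenzyl

The source may report more compounds than this note shows. Statements on the series, on what has been measured and on what is new or still open speak of the compounds shown alone.

Measured so far in a functional assay on MGC-803 cells (Homo sapiens) for inhibition, read by MTT assay, with a stated time of 72 h; on this read-out higher numbers stand for weaker inhibition and lower numbers for stronger inhibition:
compound 1 `CC(C)(C)OC(=O)N1CCN(C(=S)SCc2cn(-c3ccccc3F)nn2)CC1`: 119000 nM
compound 2 `O=C(OCc1ccccc1)N1CCN(C(=S)SCc2cn(Cc3ccc(F)cc3)nn2)CC1`: 17600 nM
compound 3 `COc1cc(Cn2cc(CSC(=S)N3CCNCC3)nn2)cc(OC)c1OC`: "not determined" (no result reported) in this assay

Compound 1 carries the highest number of the two reported, and so the weakest inhibition; compound 2 sits well below it, with a gap that lies beyond the usual scatter. Compound 2 differs from compound 1 in more than one place, so the two values show only that one is lower than the other and nothing about which part of the change carries the effect. Compound 3 has no number and cannot be placed.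

Compound 4 `CC(C)(C)OC(=O)N1CCN(C(=S)SCc2cn(Cc3ccc(Cl)c(Cl)c3)nn2)CC1` is the next compound to be tested in this assay. It differs from compound 1 in a single place: 3,4-dichlorobenzyl in place of 2-fluorophenyl on an aromatic nitrogen.

Going by the values given here, no step between measured compounds isolates this change, so the expectation rests on little. Given that compound 1 gives 119000 nM and that the only other compound with a number, compound 2, carries a benzyl-type group on the ring nitrogen and gives 17600 nM, a moderate step downward is expected from compound 1 to compound 4, of about a 3.0-fold lower number from compound 1 to compound 4 (0.47 log units; beyond the scatter). For compound 4 the expected value in this assay is 40000 nM, with a range from 10000 nM to 150000 nM.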

Compound 4, half-maximal inhibitory concentration: 33700 nM
The estimate for compound 4 lay 1.2-fold (0.07 log units) above the measured number; measured number inside the range.
By their numbers in this assay, from the lowest: compounds 2 and 4 (each within the scatter of the next); then compound 1.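

In this assay, the change from 2-fluorophenyl to 3,4-dichlorobenzyl on an aromatic nitrogen gives a 3.5-fold lower number from compound 1 to compound 4 (0.55 log units; beyond the scatter), a modest step but the first in the series that isolates a single place, with the rest of the core of compound 1 unchanged. Going by these compounds alone, the earlier values could show only that two compounds differing in more than one place had different numbers, whereas this pair shows that the group on this nitrogen can by itself move the number beyond the usual scatter. The change still combines a phenyl-to-benzyl swap with a different halogen pattern, and nothing available bears on why the number moves.

Still open, as far as these compounds go, is how a 3,4-dichlorophenyl group or an unsubstituted benzyl group would read on this nitrogen, since either would help separate the halogen pattern from the swap of phenyl for benzyl. Also open, from the compounds shown here alone, is whether a group of another kind in this place, such as a longer alkyl chain or a carboxylic acid, would move the number further, and in which direction.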